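Swapping the Indole for a Trifluoromethylphenyl Group

The source may report more compounds than this note shows. Statements on the series, on what has been measured and on what is new or still open speak of the compounds shown alone.

Compound 1 `COc1cc(-c2ccnc3cc(-c4c[nH]c5ccccc45)nn23)cc(OC)c1OC`: 195 nM
Compound 2 `COc1cc(-c2ccnc3cc(-c4ccccc4)nn23)cc(OC)c1OC`: 458 nM

Going by the values given here, in a functional assay on HeLa cells (Homo sapiens) for inhibition, read by CCK-8 assay, with a stated time of 48 h (on this read-out higher numbers stand for weaker inhibition and lower numbers for stronger inhibition), compound 1 stands lowest of the two numbers measured so far, with compound 2 the nearest. Compound 3 `COc1cc(-c2ccnc3cc(-c4ccc(C(F)(F)F)cc4)nn23)cc(OC)c1OC` differs from compound 1 in one place: 4-(trifluoromethyl)phenyl in place of 1H-indol-3-yl on an aromatic carbon. Among the compounds with values here, one measured step bears on this change, a 2.3-fold higher number from compound 1 to compound 2 (0.37 log units; beyond the scatter), which also puts phenyl in place of 1H-indol-3-yl and gave a modest rise. Within the data shown here, the trifluoromethyl group has no measured counterpart here, so a rise of similar, modest size is the plain expectation. Compound 3 is therefore expected to give 500 nM, within 200 nM to 1500 nM. That expectation amounts to a 2.6-fold higher number from compound 1 to compound 3 (0.41 log units; beyond the scatter).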

Compound 3, half-maximal inhibitory concentration: 1840 nM
Compound 3: the middle estimate sits 3.7-fold (0.57 log units) below what was measured, and the stated range ends below it.
By their numbers in this assay, from the lowest: compound 1; then compound 2; then compound 3.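

At this position, the phenyl ring is sensitive to what it carries: trifluoromethyl in place of hydrogen gives a 4.0-fold higher number from compound 2 to compound 3 (0.60 log units; beyond the scatter), so the ring's substituent matters as well as the swap away from the indole. Taken as one change, 4-(trifluoromethyl)phenyl in place of 1H-indol-3-yl gives a 9.4-fold higher number from compound 1 to compound 3 (0.97 log units; beyond the scatter). No measurement at hand accounts for this rise.

From the compounds shown here alone, whether the rise is particular to trifluoromethyl, or would also follow from a methoxy group or an amine on the phenyl ring, stays open. So does whether a pyridine ring here could match compound 1.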